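The source may report more compounds than this note shows. Statements on the series, on what has been measured and on what is new or still open speak of the compounds shown alone.

Values in a functional assay on OVCAR-8 cells (Homo sapiens) for antiproliferative activity; a lower number here means a stronger inhibitor, a higher number a weaker inhibitor:
- compound 1 `CCC[C@@H]1C[C@@H](c2ccc(Cl)c(Cl)c2)[C@H](NC(=O)c2cc(-c3c(Cl)cnn3C)c(Cl)o2)CN1`: 1620 nM
- compound 2 `Cn1ncc(Cl)c1-c1cc(C(=O)N[C@@H]2CN[C@H](CC(=O)NC3CC3)C[C@H]2c2ccc(Cl)c(Cl)c2)oc1Cl`: 580 nM
- compound 3 `Cn1ncc(Cl)c1-c1cc(C(=O)N[C@@H]2CN[C@H](CC(=O)NCCO)C[C@H]2c2ccc(Cl)c(Cl)c2)oc1Cl`: not yet measured

Compound 2 holds the lower of the two numbers, at 580 nM. The next change is 2-hydroxyethyl in place of cyclopropyl on an amide-type nitrogen, with 2-hydroxyethyl in place of cyclopropyl on an amide-type nitrogen.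

Among the measured compounds shown here, only one measured step bears on this: a 2.8-fold lower number from compound 1 to compound 2 (0.45 log units; beyond the scatter). That step is modest and put cyclopropylcarbamoyl in place of ethyl, so it shows that this side chain can shift the number in this assay. For the measured compounds named here, it does not test the group on the amide-type nitrogen, and no measured pair does. The expectation is therefore no step beyond the scatter, with a slight lean towards a higher number and a wide margin. The estimated step is a 1.3-fold higher number from compound 2 to compound 3 (0.11 log units; within the scatter). For compound 3 the expected value is 750 nM, with an estimated range of 300 nM to 1900 nM.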

Compound 3, half-maximal inhibitory concentration: 1450 nM
For compound 3 the middle estimate is 1.9-fold (0.29 log units) below the measured one, and the stated range covers the measured number.
By their numbers in this assay, from the lowest: compound 2; then compounds 3 and 1 (each within the scatter of the next).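

The group on the amide-type nitrogen matters in this assay: replacing cyclopropyl with 2-hydroxyethyl gives a step beyond the scatter (a 2.5-fold higher number from compound 2 to compound 3 (0.40 log units; beyond the scatter)), about the size of the earlier step from ethyl to cyclopropylcarbamoyl (a 2.8-fold lower number from compound 1 to compound 2 (0.45 log units; beyond the scatter)). The carbamoyl unit alone therefore does not carry the lower number in these compounds, since (2-hydroxyethyl)carbamoyl in place of ethyl stays within the scatter (a 1.1-fold lower number from compound 1 to compound 3 (0.05 log units; within the scatter)). No available evidence accounts for the difference between cyclopropyl and 2-hydroxyethyl.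

The compounds shown do not separate the effect of the ring of cyclopropyl from that of the hydroxyl of 2-hydroxyethyl. Cyclobutyl, isopropyl, 2-methoxyethyl or 2-aminoethyl on the same nitrogen would bear on that question.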